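Pentyl to benzyl on the shared core

The source may report more compounds than this note shows. Statements on the series, on what has been measured and on what is new or still open speak of the compounds shown alone.

In a functional assay on A549 cells (Homo sapiens) for antiproliferative activity, read by MTT assay, with a stated time of 48 h (on this read-out lower numbers stand for stronger inhibition and higher numbers for weaker inhibition), compound 1 `CCCCCC1(O)C(=O)Nc2ccc(Nc3ccc(C)cc3)cc21` gives 8100 nM and compound 2 `CCCCCC1(O)C(=O)Nc2ccc(Nc3ccc(F)cc3)cc21` gives 5900 nM. These two values lie within the scatter of each other, so compound 2 holds no place apart from compound 1. Going by the values given here, the only measured step is a 1.4-fold lower number from compound 1 to compound 2 (0.14 log units; within the scatter), with fluoro in place of methyl on an aromatic carbon.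

Compound 3 `O=C1Nc2ccc(Nc3ccc(F)cc3)cc2C1(O)Cc1ccccc1` keeps the fluoro of compound 2 and changes the chain: phenyl in place of butyl on a saturated chain carbon bound to a saturated ring carbon. In words, this is phenyl in place of butyl on a saturated chain carbon bound to a saturated ring carbon.

Among the compounds with values here, no measured step touches this chain, and the step at the aromatic carbon is a different change that gives only a weak guide. No clear direction follows, so no step beyond the scatter is expected in this assay. The expected step is a 1.0-fold higher number from compound 2 to compound 3 (0.01 log units; within the scatter), anchored on compound 2 at 5900 nM. For compound 3 the estimated value is 6000 nM, with an expected range of 2500 nM to 15000 nM.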

Compound 3, half-maximal inhibitory concentration: 3000 nM
Compound 3: middle estimate off by 2.0-fold (0.30 log units), on the high side; low and high end bracket the measured number.
By their numbers in this assay, from the lowest: compounds 3, 2 and 1 (each within the scatter of the next, the first and the last beyond it).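

Going by these compounds alone, the step of a 2.0-fold lower number from compound 2 to compound 3 (0.29 log units; within the scatter) is the first reading at this chain in this assay, and it is the only one at this place on the shared core. It shows that this place, a saturated chain carbon bound to a saturated ring carbon, takes phenyl in place of butyl with the fluoro kept and without a step beyond the scatter, so a chain ending in an aromatic ring and a purely saturated one cannot be told apart here. No measurement on hand bears on what lies behind this result.

An amine or a carboxylic acid at the end of this chain, or a chain longer than pentyl, remains an open test of how far this place tolerates change. As far as these compounds go, whether benzyl reads the same with methyl in place of fluoro on the aromatic carbon also stays open.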